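A few compounds are considered here, and "the series" means these few. Any claim that something is new, unique, unknown or untested is made for them only; others in the source may bear on it.

Measured so far in a functional assay on DU-145 cells (Homo sapiens) for inhibition, read by trypan blue exclusion, with a stated time of 96 h; a higher number here means a weaker inhibitor of growth, a lower number a stronger inhibitor of growth:
- compound 1 `COc1ccccc1/C=C(/SCc1ccc(Cl)c(Cl)c1)C(=O)c1ccc(Cl)cc1`: 10000 nM
- compound 2 `O=C(/C(=C\c1ccccc1OCc1ccccc1)SCc1ccc(Cl)c(Cl)c1)c1ccc(Cl)cc1`: 10000 nM
- compound 3 `CN(C)c1ccc(/C=C(/SCc2ccc(Cl)c(Cl)c2)C(=O)c2ccc(Cl)cc2)cc1`: 50000 nM

Compound 1 stands level with compound 2 at the digits shown, the two of them together the lowest of the three numbers, while compound 3 is the furthest away. The step of no change at the digits printed from compound 1 to compound 2 (within the scatter) alters only the substituent on the aromatic ether oxygen and leaves the number unchanged. The step of a 5.0-fold higher number from compound 1 to compound 3 (0.70 log units; beyond the scatter) exchanges the aryl group on the double-bonded chain carbon and is modest.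

Compound 4 `COc1ccccc1/C=C(/Sc1ccc(Br)cc1)C(=O)c1ccc(Cl)cc1` differs from compound 1 at the sulfur: 4-bromophenyl in place of 3,4-dichlorobenzyl on a sulfur. Neither measured step touches the sulfur substituent, so neither bears directly on this change; the two steps only show that one part of the scaffold tolerates a change without effect while another is modestly sensitive. For the measured compounds named here, with no step on this position, the expectation is no change beyond the scatter, with a wide range to reflect the lack of a guide: no change at the digits printed from compound 1 to compound 4 (within the scatter) is the expected step. In this assay compound 4 is expected to give 10000 nM, between 3000 nM and 40000 nM.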

Compound 4, concentration for 50% growth inhibition: 10000 nM
For compound 4 middle estimate and measured number coincide at the digits printed; low and high end bracket the measured number.
By their numbers in this assay, from the lowest: compounds 1, 2 and 4 (each within the scatter of the next); then compound 3.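

In this assay the sulfur position now has its first step, no change at the digits printed from compound 1 to compound 4 (within the scatter), with 4-bromophenyl in place of 3,4-dichlorobenzyl on a sulfur. For this pair, the substituent on the sulfur can go from 9 heavy atoms to 7, with a different halogen pattern on its single aromatic ring, and the number stays within the scatter. No evidence on why the number holds is available for this pair.

For the compounds shown here, the single step changes the benzyl chain carbon and the ring halogens together, so the share of each stays open. Also open, as far as these compounds go, is whether the number holds with a group of another kind on the sulfur, such as a longer alkyl chain or a phenyl ring bearing a carboxylic acid, and whether 4-(dimethylamino)phenyl on the double-bonded chain carbon gives the same step with 4-bromophenyl on the sulfur.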